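The compounds below may be only part of what the source reports. "The series", "measured", "known", "first", "only" and "open" are said of these compounds alone.

Measured so far:
Compound 1, `O=C(CI)NCCC(=O)NCCCCCCNc1ncnc2c1ncn2[C@@H]1O[C@H](COP(=O)(O)OP(=O)(O)OP(=O)(O)O)[C@@H](O)[C@H]1O`, in an assay on isolated protein for inhibition of hexokinase-2 (Rattus norvegicus), with a stated time of 6 h, tested at 10 mM (a higher number here means more inhibition at the concentration tested (going by the name of the read-out), a lower number less inhibition), compound 1 gives 0%.
Compound 2, `O=C(CI)NCCCCCCCNc1ncnc2c1ncn2[C@@H]1O[C@H](COP(=O)(O)OP(=O)(O)OP(=O)(O)O)[C@@H](O)[C@H]1O`, in this assay compound 2 gives 30%.

Among the measured compounds shown here, compound 2 stands highest of the two numbers; the only step known, a number 30 percentage points higher from compound 1 to compound 2 (beyond the scatter), separates it from compound 1. Compound 3, `CC(=O)NCCCCCCCCNc1ncnc2c1ncn2[C@@H]1O[C@H](COP(=O)(O)OP(=O)(O)OP(=O)(O)O)[C@@H](O)[C@H]1O`, differs from compound 2 by acetamidomethyl in place of ((iodomethyl)carbonyl)amino on a saturated chain carbon, seven bonds along the chain from a nitrogen on an aromatic ring. For the measured compounds named here, the one measured step kept the iodine on both sides, so no measured step bears on removing it. Compound 3 is therefore expected to lose inhibition, an estimated step of a number 22 percentage points lower from compound 2 to compound 3 (beyond the scatter). The estimate for compound 3 is 8%, within 0% to 30%.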

Compound 3, a percentage reported as inhibition, at one concentration (the size of the read-out at that concentration, not a potency): -12%
Compound 3: the middle estimate sits 20 percentage points above what was measured, outside the stated range (below it).
By their numbers in this assay, from the lowest: compound 3; then compound 1; then compound 2.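

In this assay, among the compounds shown here, replacing ((iodomethyl)carbonyl)amino with acetamidomethyl gives a number 42 percentage points lower from compound 2 to compound 3 (beyond the scatter) and is the first measured change that removes the iodine. The larger change at the chain end gives a number 12 percentage points lower from compound 1 to compound 3 (beyond the scatter) and leaves the iodine-free compound lowest of the three, so inhibition here is sensitive to what ends the chain. Nothing available explains why this drop occurs.

Going by these compounds, whether the iodine itself matters remains open, since a chloroacetyl group at the chain end would test this. A free amine there, or a longer chain, is also untested in the compounds shown.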